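The source may hold more compounds than are shown below. What is called first, only, known or untested is meant among the compounds shown, and "the series" means these compounds.

Measured in an ADME assay on MRC5 cells (Homo sapiens) for cytotoxicity, read by fluorescence, with a stated time of 72 h; a lower number here means a stronger inhibitor, a higher number a weaker inhibitor:
compound 1 `O=[N+]([O-])c1cn2c(n1)OC(COc1ccc(-c3ccc(C(F)(F)F)cc3)nc1)C2`: > 64000 nM
compound 2 `CC1(COc2ccc(-c3ccc(C(F)(F)F)cc3)nc2)Cn2cc([N+](=O)[O-])nc2O1`: > 64000 nM

Compound 2 gives > 64000 nM, which is a limit of the assay and not a number. Compound 1 gives > 64000 nM, which is also a limit. Compound 2 therefore has no measured position within the range of the assay, only (the limit of > 64000 nM in this assay, at which 2 of the 2 values shown sit).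

Compound 3 `CC1(COc2ccc(-c3ccc(F)nc3)nc2)Cn2cc([N+](=O)[O-])nc2O1` carries 6-fluoropyridin-3-yl in place of 4-(trifluoromethyl)phenyl on an aromatic carbon, next to the ring nitrogen: 6-fluoropyridin-3-yl in place of 4-(trifluoromethyl)phenyl on an aromatic carbon.

For the measured compounds named here, the only measured step is a step that the two limits leave unreadable from compound 1 to compound 2. It concerns methyl in place of hydrogen on a saturated ring carbon, a different change at a different place, and it gives no size to carry over. Going by the values given here, no measured step tests the aryl exchange.

Because of the limit of > 64000 nM in this assay, at which 2 of the 2 values shown sit, the working expectation in this assay is that compound 3 also reports a limit, with no step beyond the scatter. A readable number, if one appears, could only lie on the stronger side of that limit.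

The expected change is a number no higher from compound 2 to compound 3 (the limit leaves the size open).

For compound 3 the estimated value is 64000 nM, with an expected range of 30000 nM to 64000 nM.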

Compound 3, half-maximal inhibitory concentration: > 64000 nM
Compound 3 ended at the assay's limit (the forecaster's own chance of this, stated with the estimate: 75%); the middle value sits exactly at the limit.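

In this assay compound 3 gives > 64000 nM, a limit of the assay and not a number. No step can be read between compound 2 and compound 3, because both report a limit: the limit of > 64000 nM in this assay, at which 3 of the 3 values shown sit. The compounds shown leave open whether exchanging 4-(trifluoromethyl)phenyl for 6-fluoropyridin-3-yl changes the read-out at all.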